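This account rests on a few compounds, and the source may have more. Where it says the series, first, only, none or still open, it means among the compounds named here.

Measured so far:
compound 1 `ClCc1cccc(Cn2cnc3c(Cl)nc(Cl)nc32)c1` — 45700 nM
compound 2 `Nc1nc(Cl)c2ncn(Cc3ccc(CCl)cc3)c2n1` — 72400 nM
compound 3 `ClCc1cccc(Cn2cnc3nc(Cl)nc(Cl)c32)c1` — 6300 nM

In a functional assay on SF-295 cells (Homo sapiens) for cytotoxicity, read by sulforhodamine B assay, with a stated time of 48 h (a lower number here means that less compound is tolerated, a higher number that more compound is tolerated), compound 3 gives the lowest of the three numbers; compound 1 and compound 2 both lie beyond the usual scatter above it, so compound 3 is the one of which the cells tolerate least. Compound 4 `ClCc1cccc(Cn2cnc3ncnc(Cl)c32)c1` has not been measured yet. It differs from compound 3 in one place: hydrogen in place of chloro on an aromatic carbon. Among the compounds with values here, no two measured compounds differ in only one place, so there is no measured step of this kind to lean on. Removing a chloro is expected to give a small to moderate rise in the number, a 1.9-fold higher number from compound 3 to compound 4 (0.28 log units; within the scatter), with direction uncertain. Compound 4 is therefore estimated at 12000 nM, within a range of 4000 nM to 40000 nM.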

Compound 4, concentration lethal to 50% of the cells: 64600 nM
For compound 4 the middle estimate is 5.4-fold (0.73 log units) below the measured one; measured number above the stated range.
By their numbers in this assay, from the lowest: compound 3; then compounds 1, 4 and 2 (each within the scatter of the next).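

In this assay, within the data shown here, this is the first single change that can be read: putting hydrogen in place of the chloro on the aromatic carbon between two ring nitrogen atoms gives a 10-fold higher number from compound 3 to compound 4 (1.01 log units; beyond the scatter) and so shows that this one atom matters greatly. The low number of compound 3 therefore depends on this chloro. Nothing measured here bears on why the number moves. From the compounds shown here alone, what a fluoro, a methoxy group or an amine on this carbon would do remains open, as does the effect of the chloro at other positions.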